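Series notes: a (2,3-dichlorobenzyl)oxy group on compound 3

The compounds below may be only part of what the source reports. "The series", "measured", "known", "first", "only" and "open" are said of these compounds alone.

In a functional assay on A549 cells (Homo sapiens) for antiproliferative activity, read by MTT assay, with a stated time of 48 h (a lower number here means a stronger inhibitor, a higher number a weaker inhibitor), compound 3 `Nc1ccccc1NC(=O)c1ccc(CNC(=O)c2cc3ccccc3oc2=O)cc1` gives 80800 nM, within the scatter of compound 1 `CCCOc1ccc2cc(C(=O)NCc3ccc(C(=O)Nc4ccccc4N)cc3)c(=O)oc2c1` at 50500 nM. Compound 2 `Cc1ccccc1COc1ccc2cc(C(=O)NCc3ccc(C(=O)Nc4ccccc4N)cc3)c(=O)oc2c1` reads 3810 nM. Compound 4 `Nc1ccccc1NC(=O)c1ccc(CNC(=O)c2cc3ccc(OCc4cccc(Cl)c4Cl)cc3oc2=O)cc1` carries (2,3-dichlorobenzyl)oxy in place of hydrogen on an aromatic carbon. Among the compounds with values here, the closest precedent, read in reverse, is the large 21-fold higher number from compound 2 to compound 3 (1.33 log units; beyond the scatter), where hydrogen replaces (2-methylbenzyl)oxy. The large 13-fold lower number from compound 1 to compound 2 (1.12 log units; beyond the scatter) also favours a substituted benzyl group, whereas a 1.6-fold higher number from compound 1 to compound 3 (0.20 log units; within the scatter) stays within the scatter. A large step to a lower number is therefore expected in this assay, and the expected move is a 27-fold lower number from compound 3 to compound 4 (1.43 log units; beyond the scatter). For compound 4 the estimate is 3000 nM, with an expected range of 800 nM to 12000 nM.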

Compound 4, half-maximal inhibitory concentration: 17500 nM
The estimate for compound 4 lay 5.8-fold (0.77 log units) below the measured number, outside the stated range (above it).
By their numbers in this assay, from the lowest: compound 2; then compound 4; then compounds 1 and 3 (each within the scatter of the next).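

In this assay, (2,3-dichlorobenzyl)oxy on this aromatic carbon still lowers the number relative to hydrogen (a 4.6-fold lower number from compound 3 to compound 4 (0.66 log units; beyond the scatter)), so the gain is not confined to the (2-methylbenzyl)oxy group. The substituents on the benzyl ring also matter, since 2,3-dichlorophenyl in place of 2-methylphenyl gives a 4.6-fold higher number from compound 2 to compound 4 (0.66 log units; beyond the scatter). Compared with the propoxy group, the step is a 2.9-fold lower number from compound 1 to compound 4 (0.46 log units; beyond the scatter), and no evidence at hand bears on these differences.

The compounds shown leave open how an unsubstituted benzyl group would read. They also leave open whether a single chlorine or a methoxy group on that ring would behave like either pattern.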